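A Chain Shortened Once More in a Rat Study

The compounds below may be only part of what the source reports. "The series", "measured", "known", "first", "only" and "open" are said of these compounds alone.

Of the compounds shown here, three have been measured in a functional assay on the whole organism for inhibition, with Rattus norvegicus as the target, at a dose of 15 mg/kg by the intravenous route; on this read-out higher numbers stand for more inhibition at the one dose given (going by the name of the read-out) and lower numbers for less inhibition. Compound 1 `CCCC1Nc2ccc(C(C)C)cc2C(=O)N1Cc1ccc(-c2ccccc2-c2nn[nH]n2)cc1` gives 88%, compound 3 `CCC1Nc2ccc(C(C)C)cc2C(=O)N1Cc1ccc(-c2ccccc2-c2nn[nH]n2)cc1` gives 88%, and compound 2 `CCCCC1N(Cc2ccc(-c3ccccc3-c3nn[nH]n3)cc2)C(=O)c2ccccc2N1C` gives 88%. Compound 1 and compound 3 differ by hydrogen in place of methyl on a saturated chain carbon, two bonds along the chain from a saturated ring carbon, and the step of no change at the digits printed from compound 1 to compound 3 (within the scatter). Compound 2 stands level with compound 1 and compound 3 at the digits shown; how its core differs from the core of compound 1 is not broken down here.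

Compound 4 `CCCC1N(Cc2ccc(-c3ccccc3-c3nn[nH]n3)cc2)C(=O)c2ccccc2N1C` has not yet been measured. It differs from compound 2 by hydrogen in place of methyl on a saturated chain carbon, three bonds along the chain from a saturated ring carbon. Going by the values given here, this is the same kind of change as the one from compound 1 to compound 3, but the place is three bonds along the chain from a saturated ring carbon rather than two. Because the earlier step of no change at the digits printed from compound 1 to compound 3 (within the scatter) stayed within the scatter, the step of no change at the digits printed from compound 2 to compound 4 (within the scatter) is expected to be of a similarly small size in this assay. Compound 4 is therefore estimated at 88%, with a likely range from 78% to 95%.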

Compound 4, a percentage reported as inhibition, in the whole organism at one dose (the size of the read-out at that dose, not a potency): 88%
Compound 4: middle estimate and measured number agree at the digits printed; measured number inside the range.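

Shortening butyl to propyl on the core of compound 2 gives no change at the digits printed from compound 2 to compound 4 (within the scatter), and set beside the step on the core of compound 1, propyl to ethyl, the two agree in this assay: the same change on two cores in this assay, no change at the digits printed (within the scatter) from compound 1 to compound 3 and no change at the digits printed (within the scatter) from compound 2 to compound 4, 0 percentage points apart, within the scatter of two such steps

In these two pairs, then, the change carries from one core to the other without moving the read-out. This does not show that the two cores respond alike in general: the change sits at a different place along the chain in each pair, neither step moves the read-out, and a percentage at one dose is not a potency, so any difference that this dose does not reveal stays out of view.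

The compounds shown leave open whether a longer chain than butyl, or an amine or a carboxylic acid in place of the chain, would stay level with these compounds. They also leave open whether these compounds would stay level at a lower dose.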